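The source may hold more compounds than are shown below. What is called first, only, known or untested is meant among the compounds shown, and "the series" means these compounds.

Compound 1 `Cc1ccc(C(=O)Nc2cccc(-c3oc4cc(-c5ccc(F)cc5)ccc4c(=O)c3O)c2)cc1` gives 4350 nM in a functional assay on MDA-MB-231 cells (Homo sapiens) for antiproliferative activity, read by CCK-8 assay, with a stated time of 72 h; on this read-out lower numbers stand for stronger inhibition and higher numbers for weaker inhibition. Compound 2 `Cc1cccc(C(=O)Nc2cccc(-c3oc4cc(-c5ccc(F)cc5)ccc4c(=O)c3O)c2)c1` gives 2840 nM. Compound 3 `O=C(Nc1cccc(-c2oc3cc(-c4ccc(F)cc4)ccc3c(=O)c2O)c1)c1cccc(F)c1` gives 2510 nM.

Three amides on a shared core were measured. Of the three numbers, that of compound 3 sits lowest on the page, but this sets it apart from neither neighbour: a 1.1-fold lower number from compound 2 to compound 3 (0.05 log units; within the scatter), and a 1.7-fold lower number from compound 1 to compound 3 (0.24 log units; within the scatter). The remaining pair also stays within the scatter: a 1.5-fold lower number from compound 1 to compound 2 (0.19 log units; within the scatter).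

Compound 4 `O=C(Nc1cccc(-c2oc3cc(-c4ccc(F)cc4)ccc3c(=O)c2O)c1)c1cc(F)cc(F)c1` differs from compound 3 in a single place: fluoro in place of hydrogen on an aromatic carbon. The step that bears most directly on this is the one in which fluoro replaced methyl on an aromatic carbon, a 1.1-fold lower number from compound 2 to compound 3 (0.05 log units; within the scatter), which remained within the scatter; the swap of one substituted phenyl for another, a 1.7-fold lower number from compound 1 to compound 3 (0.24 log units; within the scatter), did the same. Going by the values given here, no measured compound carries two fluoro groups on this ring, so the expectation for compound 4 is a step no larger than the scatter, in either direction, from compound 3: a 1.1-fold lower number from compound 3 to compound 4 (0.06 log units; within the scatter). Compound 4 is therefore estimated at 2200 nM, with a range from 1000 nM to 5000 nM.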

Compound 4, half-maximal inhibitory concentration: 2440 nM
For compound 4 the middle estimate is 1.1-fold (0.04 log units) below the measured one; low and high end bracket the measured number.
By their numbers in this assay, from the lowest: compounds 4, 3, 2 and 1 (each within the scatter of the next).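

Placing a second fluoro on the ring, to give 3,5-difluorophenyl, does not separate compound 4 from its parent in this assay, with a 1.0-fold lower number from compound 3 to compound 4 (0.01 log units; within the scatter) as the step. The 3,5-difluorophenyl amide also stays level with both methyl-bearing amides, with a 1.2-fold lower number from compound 2 to compound 4 (0.07 log units; within the scatter) as one step and a 1.8-fold lower number from compound 1 to compound 4 (0.25 log units; within the scatter) as the other, so none of the four compounds stands apart from the rest on this read-out. Nothing available on these compounds accounts for this flat picture.

From the compounds shown here alone, only methyl and fluoro appear on this ring, so it remains open whether an amine, a carboxylic acid or a longer chain here would produce a step beyond the scatter. Also open, going by these compounds, is whether this flat picture would hold with a different group in place of the amide link.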